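Methoxy for Methyl on the Aryl Group of Compound 2

This account rests on a few compounds, and the source may have more. Where it says the series, first, only, none or still open, it means among the compounds named here.

Compound 1 `CN1C(=O)[C@@]2(c3ccccc31)N(C)C[C@@H](c1ccco1)[C@@]21Cc2ccccc2C1=O` and compound 2 `Cc1ccc([C@@H]2CN(C)[C@]3(C(=O)N(C)c4ccccc43)[C@]23Cc2ccccc2C3=O)cc1` share one core and differ in a single group on a saturated ring carbon. In a functional assay on the whole organism (strain Wister albino) for inhibition, with Rattus norvegicus as the target, read by paw edema, with a stated time of 1 h, at a dose of 50 mg/kg by the intraperitoneal route (on this read-out higher numbers stand for more inhibition at the one dose given (going by the name of the read-out) and lower numbers for less inhibition), compound 1 gives 50.1%, and compound 2 gives 46.9%. The one measured step, a number 3.2 percentage points lower from compound 1 to compound 2 (within the scatter), lies within the scatter, so compound 2 holds the lower of the two numbers shown only nominally, its sole neighbour sitting within the scatter of it. Compound 3 `COc1ccc([C@@H]2CN(C)[C@]3(C(=O)N(C)c4ccccc43)[C@]23Cc2ccccc2C3=O)cc1` has yet to be measured in this assay. It differs from compound 2 by methoxy in place of methyl on an aromatic carbon. For the measured compounds named here, no measured step bears directly on this change; the only step available changed a different group and was itself within the scatter. One therefore expects no step beyond the scatter, an estimated a number 0.1 percentage points higher from compound 2 to compound 3 (within the scatter). For compound 3 the estimate in this assay is 47%, with a range from 36% to 58%.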

Compound 3, a percentage reported as inhibition, in the whole organism at one dose (the size of the read-out at that dose, not a potency): 46.9%
For compound 3 the middle estimate is 0.1 percentage points above the measured one; the range from low to high includes it.
By their numbers in this assay, from the lowest: compounds 2, 3 and 1 (each within the scatter of the next).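

In this assay, methoxy in place of methyl on an aromatic carbon, para to a large group, gives no change at the digits printed from compound 2 to compound 3 (within the scatter) and so adds a hydrogen-bond acceptor at this position with no visible effect on the read-out. The comparison of 4-methoxyphenyl with furan-2-yl on the saturated ring carbon gives a number 3.2 percentage points lower from compound 1 to compound 3 (within the scatter) and so matches the earlier comparison with 4-methylphenyl: all three groups now read alike at this one dose. Nothing available accounts for this flat result.

From the compounds shown here alone, whether an amine or a carboxylic acid at the same aromatic carbon, or a chain longer than methoxy, would move the inhibition beyond the scatter remains open. Also open, going by these compounds, is whether the three compounds would still read alike at other doses or at later times.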